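The source may hold more compounds than are shown below. What is called first, only, known or untested is meant among the compounds shown, and "the series" means these compounds.

- compound 1 `O=C(Nc1cccc(-c2nc3ccccc3s2)c1)c1cc([N+](=O)[O-])c(O)cc1Cl` gives 2200 nM in the first measurement
- compound 2 `COc1ccc(-c2nc3ccccc3o2)cc1NC(=O)c1cc([N+](=O)[O-])ccc1Cl` gives 90 nM in the second measurement

In a physicochemical assay for solubility, read by spectrophotometry, in phosphate buffer, measured as kinetic solubility, with a stated time of 18 h, at pH 7.4 (a higher number here means a more soluble compound, a lower number a less soluble compound), compound 1 stands highest of the two numbers, and compound 2 sits lower, beyond the usual scatter. Compound 3 `COc1cc(Cl)c(C(=O)Nc2cccc(-c3nc4ccccc4s3)c2)cc1[N+](=O)[O-]` has not yet been measured. Compared with compound 1, it turns hydroxy to methoxy, with methyl in place of hydrogen on an oxygen on an aromatic ring. Among the compounds with values here, no measured pair shows this change, so its size is uncertain. A fall beyond the scatter is expected in this assay here. The estimate means a 3.7-fold lower number from compound 1 to compound 3 (0.56 log units; beyond the scatter) as the expected step. Compound 3 is expected to give 600 nM within a range from 120 nM to 2500 nM in this estimate.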

Compound 3, solubility: 10 nM
For compound 3 the middle estimate is 60-fold (1.78 log units) above the measured one, and the stated range ends above it.
By their numbers in this assay, from the lowest: compound 3; then compound 2; then compound 1.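

Within the data shown here, this is the first pair of compounds that differ in one place, so the change from hydroxy to methoxy can now be read on its own: in this assay there is a 220-fold lower number from compound 1 to compound 3 (2.34 log units; beyond the scatter). A single methyl in place of hydrogen on this oxygen is enough to produce a large step. Nothing measured here explains its size.

On these data alone, whether a longer chain on the same oxygen, such as ethyl, would give a similar step in this assay stays open. So does how an amine or a carboxylic acid in place of the hydroxy would read.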